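Predicting cytotoxicity after swapping the benzyl ring substituents

The compounds below may be only part of what the source reports. "The series", "measured", "known", "first", "only" and "open" are said of these compounds alone.

Measured compounds and their cytotoxicity values:
- compound 1, `N#Cc1ccc(Nc2nccc(OCc3cccc(Cl)c3)n2)cc1`: 153000 nM
- compound 2, `N#Cc1ccc(Nc2nccc(OCc3ccc(Br)cc3)n2)cc1`: 16000 nM
- compound 3, `Cc1ccccc1COc1ccnc(Nc2ccc(C#N)cc2)n1`: 12000 nM

All three compounds share a core in which an aromatic ring bearing a nitrile is linked through a nitrogen to a second ring, which carries an oxygen-bound saturated chain carbon and, on it, a substituted phenyl group. In an ADME assay on MT4 cells (Homo sapiens) for cytotoxicity, read by MTT assay, with a stated time of 5 days (on this read-out lower numbers stand for higher toxicity in this test and higher numbers for lower toxicity in this test), compound 1 gives 153000 nM, the highest number of the three, so it is the least toxic in this test. The step of a 9.6-fold lower number from compound 1 to compound 2 (0.98 log units; beyond the scatter) and the step of a 13-fold lower number from compound 1 to compound 3 (1.11 log units; beyond the scatter) both go in the same direction, toward higher toxicity, while the two lower values differ only by a 1.3-fold lower number from compound 2 to compound 3 (0.12 log units; within the scatter).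

Compound 4, `N#Cc1ccc(Nc2nccc(OCc3ccc(Br)cc3F)n2)cc1`, has not yet been measured in this assay. It differs from compound 1 as follows: 4-bromo-2-fluorophenyl in place of 3-chlorophenyl on a saturated chain carbon bound to an oxygen on an aromatic ring. The group that enters differs from the 4-bromophenyl group of compound 2 only by its fluorine, so the step from compound 1 to compound 2 bears most directly on this change. A step of similar size and direction is therefore expected, a 10-fold lower number from compound 1 to compound 4 (1.01 log units; beyond the scatter), giving compound 4 an estimated value of 15000 nM, with a likely range from 5000 nM to 45000 nM.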

Compound 4, half-maximal cytotoxic concentration: 141000 nM
Compound 4: the middle estimate sits 9.4-fold (0.97 log units) below what was measured; the whole stated range lies below it.
By their numbers in this assay, from the lowest: compounds 3 and 2 (each within the scatter of the next); then compounds 4 and 1 (each within the scatter of the next).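

The fluoro group is what matters here: in this assay, fluoro in place of hydrogen on an aromatic carbon gives an 8.8-fold higher number from compound 2 to compound 4 (0.95 log units; beyond the scatter), a step beyond the scatter from a single added atom on the phenyl group. The earlier compounds shown here could suggest that moving away from 3-chlorophenyl on this saturated chain carbon bound to an oxygen on an aromatic ring brings more toxicity in this test, but 4-bromo-2-fluorophenyl goes against that, with a 1.1-fold lower number from compound 1 to compound 4 (0.04 log units; within the scatter), within the scatter. The contrast with 2-methylphenyl, a 12-fold higher number from compound 3 to compound 4 (1.07 log units; beyond the scatter), shows that this place can hold a large phenyl group with a bromine and still give a high number, so the bromine alone does not set the low value of compound 2.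

Going by these compounds, it stays open whether the effect belongs to fluoro itself or would also appear with a chloro or methoxy group in its place, and whether fluoro would act the same way on a phenyl group without the bromine. Nothing shown here explains why this one change moves the number so far.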